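The source may report more compounds than this note shows. Statements on the series, on what has been measured and on what is new or still open speak of the compounds shown alone.

Working notes on the series, read in an ADME assay on MT4 cells (Homo sapiens) for cytotoxicity, read by XTT assay, with a stated time of 5 days; a lower number here means that less compound is tolerated, a higher number that more compound is tolerated. Compound 3 (`COC(=O)N[C@H](C(=O)NN(CC[C@@](O)(Cc1ccccc1)C(=O)N[C@H]1c2ccccc2C[C@H]1O)Cc1ccc(-c2ccc(NC(C)=O)cc2)cc1)C(C)(C)C`) stands at > 10000 nM, which is a limit and not a number. Compound 1 (`COC(=O)N[C@H](C(=O)NN(CC[C@@](O)(Cc1ccccc1)C(=O)N[C@H]1c2ccccc2C[C@H]1O)Cc1ccc(-c2ccccn2)cc1)C(C)(C)C`) also stands at a limit, > 10000 nM. Compound 2 (`COC(=O)N[C@H](C(=O)NN(CC[C@@](O)(Cc1ccccc1)C(=O)N[C@H]1c2ccccc2C[C@H]1O)Cc1ccc(-c2cccnc2)cc1)C(C)(C)C`) gives a number, 4900 nM.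

Compound 4 (`COC(=O)N[C@H](C(=O)NN(CC[C@@](O)(Cc1ccccc1)C(=O)N[C@H]1c2ccccc2C[C@H]1O)Cc1ccccc1)C(C)(C)C`) has hydrogen in place of 4-acetamidophenyl on an aromatic carbon of the shared core: hydrogen in place of 4-acetamidophenyl on an aromatic carbon.

The nearest evidence is the set of measured swaps among aromatic groups: an at least 2.0-fold lower number from compound 1 to compound 2 (0.30 log units; that floor lies within the scatter), an at least 2.0-fold higher number from compound 2 to compound 3 (0.30 log units; that floor lies within the scatter) and a step that the two limits leave unreadable from compound 1 to compound 3. The two readable floors lie within the scatter, and the third step cannot be sized. Going by the values given here, no measured compound has hydrogen at this place, so these steps bear on the change only indirectly. Among the compounds with values here, the series so far is marked by the limit of > 10000 nM in this assay, at which 2 of the 3 values shown sit.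

No step beyond the scatter is expected, in either direction, and the expected step is a number no higher from compound 3 to compound 4 (the limit leaves the size open). The estimate for compound 4 is 10000 nM, with an expected range of 4000 nM to 25000 nM.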

Compound 4, half-maximal cytotoxic concentration: > 10000 nM
Compound 4 ended at the assay's limit (the forecaster's own chance of this, stated with the estimate: 65%); the middle value lies on the limit itself.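

In this assay compound 4 stands at > 10000 nM, which is a limit. Set against the only number in the series, the change reads as an at least 2.0-fold higher number from compound 2 to compound 4 (0.30 log units; that floor lies within the scatter); the steps to compound 4 from compound 1 and from compound 3 cannot be read. Hydrogen on this aromatic carbon thus reaches the same limit as the 4-acetamidophenyl and pyridin-2-yl groups, so an aromatic group at this place is not needed for a compound to sit there, and the limit now covers most of the series: the limit of > 10000 nM in this assay, at which 3 of the 4 values shown sit.

Whether hydrogen, pyridin-2-yl and 4-acetamidophenyl differ at all stays hidden behind the limit. From the compounds shown here alone, it also stays open whether a basic amine, a carboxylic acid or a longer chain at this place would give a number within the range of the assay.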